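The source may hold more compounds than are shown below. What is called first, only, known or untested is meant among the compounds shown, and "the series" means these compounds.

Among the measured compounds shown here, compound 3 `COC(=O)c1cc(-c2cccc(NC(=O)c3ccc(OCc4ccc(Cl)cc4)cc3)c2)on1` is one of three compounds measured in an ADME assay on Vero cells (Chlorocebus sabaeus) for cytotoxicity, read by MTT assay, with a stated time of 72 h (on this read-out lower numbers stand for higher toxicity in this test and higher numbers for lower toxicity in this test), and the account follows the change that leads from it to compound 4 `COC(=O)c1cc(-c2cccc(NC(=O)c3ccc(C4OC4C(=O)c4ccc(Cl)cc4)cc3)c2)on1`, which has not yet been measured there. In this assay compound 3 gives only a limit, > 80 ug/mL. Compound 2 `COC(=O)c1cc(-c2cccc(NC(=O)c3ccc(/C=C/C(=O)c4ccc(OC)cc4)cc3)c2)on1` likewise gives only a limit in this assay, > 10 ug/mL. For compound 1 `COC(=O)c1cc(-c2cccc(NC(=O)c3ccc(/C=C/C(=O)c4cccnc4)cc3)c2)on1` this assay reports "not determined" (no result reported). The step that the two limits leave unreadable from compound 2 to compound 3 is unreadable since both of its ends sit at limits the limit of > 10 ug/mL in this assay, at which 1 of the 3 values shown sits, and (the limit of > 80 ug/mL in this assay, at which 1 of the 3 values shown sits). Compound 3 thus stands at the higher of the two limits shown, with no single number among the three entries to place it against.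

The change from compound 3 to compound 4 is 3-((4-chlorophenyl)carbonyl)oxiran-2-yl in place of (4-chlorobenzyl)oxy on an aromatic carbon. For the measured compounds named here, no measured step among the three compounds covers this change; the only step that differs in one place, from compound 2 to compound 3, has no readable size. The expectation for compound 4 in this assay therefore rests on the limit of compound 3 alone, and a step of an at least 2.0-fold lower number from compound 3 to compound 4 (0.30 log units; that floor lies within the scatter) toward lower numbers is estimated with wide uncertainty. Compound 4 is expected to give about 40 ug/mL, in a range from 10 ug/mL to 100 ug/mL.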

Compound 4, half-maximal cytotoxic concentration: > 20 ug/mL
Compound 4 gave a limit, no number; the forecaster's own chance of this, stated with the estimate: 45%; the middle value lies beyond the limit too.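

In this assay compound 4 gives only a limit, > 20 ug/mL, and its steps to compound 2 and compound 3, which also stand at limits, cannot be read. The compounds shown leave open whether 3-((4-chlorophenyl)carbonyl)oxiran-2-yl in place of (4-chlorobenzyl)oxy changes the half-maximal cytotoxic concentration at all, and in which direction.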